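This account rests on a few compounds, and the source may have more. Where it says the series, first, only, none or still open, it means among the compounds named here.

Measured in an ADME assay on BHK-21 cells (Mesocricetus auratus) for cytotoxicity, read by MTT assay, with a stated time of 72 h; on this read-out higher numbers stand for lower toxicity in this test and lower numbers for higher toxicity in this test:

Compound 1 `FC(F)(F)c1ccc(-c2nn(-c3ccccc3)cc2CNc2ccc(Cl)cc2)cc1`: 31000 nM
Compound 2 `Cc1ccc(NCc2cn(-c3ccccc3)nc2-c2ccc(C(F)(F)F)cc2)cc1`: 88000 nM

Of these two, compound 2 stands highest at 88000 nM in this assay, and the nearest number is that of compound 1 at 31000 nM. Within the data shown here, the one measured step is a 2.8-fold higher number from compound 1 to compound 2 (0.45 log units; beyond the scatter), with methyl in place of chloro on an aromatic carbon.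

Compound 3 `Cc1ccc(NCc2cn(-c3ccccc3)nc2-c2ccc(Br)cc2)cc1` keeps the methyl of compound 2 and changes another group: bromo in place of trifluoromethyl on an aromatic carbon. In words, this is bromo in place of trifluoromethyl on an aromatic carbon, para to a large group. Among the measured compounds shown here, compound 1 and compound 2 both carry the trifluoromethyl, so no measured step touches that group, and the data give no direction for this change. For the measured compounds named here, the only guide to size is the modest 2.8-fold higher number from compound 1 to compound 2 (0.45 log units; beyond the scatter), so a step of similar or smaller size is expected in this assay, possibly none beyond the scatter. The expected step is a 1.2-fold lower number from compound 2 to compound 3 (0.07 log units; within the scatter). The estimate for compound 3 is 75000 nM, with an expected range of 33000 nM to 170000 nM.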

Compound 3, half-maximal cytotoxic concentration: > 100000 nM
Compound 3: no number, only a limit; the forecaster's own chance of this, stated with the estimate: 15%; middle value at least 1.3-fold (0.12 log units) away from the limit.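

In this assay compound 3 gives > 100000 nM, which is a limit of the assay and not a number. Among these compounds, the earlier compounds both carried the trifluoromethyl, so this is the first reading of any change at this place, on an aromatic carbon para to a large group, and it is an at least 1.1-fold higher number from compound 2 to compound 3 (0.05 log units; that floor lies within the scatter). It shows that going from 4-(trifluoromethyl)phenyl to 4-bromophenyl does not bring the number down in this test, but only a floor can be read, and the true size of the step stays unknown because compound 3 has no number of its own: the limit of > 100000 nM in this assay, at which 1 of the 3 values shown sits.

The compounds shown leave open how far compound 3 lies past that limit, and so whether this change matters at all beyond the scatter or is larger than the step seen when methyl took the place of chloro. Among the compounds shown here, they also leave open what a carboxylic acid, an amine or a methoxy group would do at this place in this assay, as the only groups seen there so far are trifluoromethyl and bromo.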